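Shortening the sulfur-bound chain on a shared selenium-containing core

The source may report more compounds than this note shows. Statements on the series, on what has been measured and on what is new or still open speak of the compounds shown alone.

Three compounds share one core and differ only in the group on a sulfur. In a functional assay on HeLa cells (Homo sapiens) for antiproliferative activity, read by CCK-8 assay, with a stated time of 48 h (a lower number here means a stronger inhibitor, a higher number a weaker inhibitor), compound 1 `CC(C)CSc1n[nH]c(-n2[se]c3ccccc3c2=O)n1` gives 34900 nM and compound 2 `CCCCCCSc1n[nH]c(-n2[se]c3ccccc3c2=O)n1` gives 35900 nM, the highest of the three numbers. Compound 3 `O=c1c2ccccc2[se]n1-c1nc(SCc2ccc([N+](=O)[O-])cc2)n[nH]1` gives 3940 nM in this assay, a lower number than compound 2 shows. Compound 4 `CC(C)Sc1n[nH]c(-n2[se]c3ccccc3c2=O)n1` carries the change (isopropyl in place of hexyl on a sulfur). Within the data shown here, the one step that bears on it, a 1.0-fold higher number from compound 1 to compound 2 (0.01 log units; within the scatter), changed the chain length on that sulfur and moved nothing beyond the scatter. A further shortening is therefore expected to leave this assay unchanged within the scatter, so the expected step is a 1.0-fold lower number from compound 2 to compound 4 (0.01 log units; within the scatter). Compound 4 is estimated at 35000 nM, in the range 17000 nM to 72000 nM.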

Compound 4, half-maximal inhibitory concentration: 34600 nM
For compound 4 the middle estimate is 1.0-fold (0.00 log units) above the measured one; the measured number falls inside the stated range.
By their numbers in this assay, from the lowest: compound 3; then compounds 4, 1 and 2 (each within the scatter of the next).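

Changing the group on the sulfur from hexyl to isopropyl gives a 1.0-fold lower number from compound 2 to compound 4 (0.02 log units; within the scatter) in this assay and changing it from isobutyl to isopropyl gives a 1.0-fold lower number from compound 1 to compound 4 (0.00 log units; within the scatter) in the same assay. The earlier step compared only two longer chains, whereas these steps show that the shorter isopropyl also leaves the number within the scatter of both. No available evidence explains this lack of change.

A plain benzyl group would help show which part of the group on compound 3 goes with its lower number. On these data alone, whether an amine or a carboxylic acid on the chain would shift the number remains open.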